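This account rests on a few compounds, and the source may have more. Where it says the series, first, only, none or still open, it means among the compounds named here.

Working notes on an assay on VSM-A10 cells for antagonist activity at Endothelin-1 receptor (Rattus norvegicus); a lower number here means a stronger inhibitor, a higher number a weaker inhibitor. Compound 1 `Cc1noc(NS(=O)(=O)c2cccc3c(N4CCCCC4=O)cccc23)c1C` gives 270 nM. Compound 2 `CNc1cccc2c(S(=O)(=O)Nc3onc(C)c3C)cccc12` gives 130 nM. Compound 3 `CCCCCNc1cccc2c(S(=O)(=O)Nc3onc(C)c3C)cccc12` gives 80 nM, the lowest of the three numbers; its gap to compound 1 is beyond the scatter, its gap to compound 2 within it. The measured steps are a 2.1-fold lower number from compound 1 to compound 2 (0.32 log units; beyond the scatter), a 3.4-fold lower number from compound 1 to compound 3 (0.53 log units; beyond the scatter) and a 1.6-fold lower number from compound 2 to compound 3 (0.21 log units; within the scatter). Among the measured compounds shown here, compound 4 `Cc1noc(NS(=O)(=O)c2cccc3c(Cl)cccc23)c1C` is not yet measured. chloro in place of pentylamino on an aromatic carbon The steps that bear on this change are a 3.4-fold lower number from compound 1 to compound 3 (0.53 log units; beyond the scatter), a modest gain, and a 1.6-fold lower number from compound 2 to compound 3 (0.21 log units; within the scatter), within the scatter. For the measured compounds named here, no measured compound carries chloro at this position, so the step is uncertain; a modest rise in number is expected, a 2.8-fold higher number from compound 3 to compound 4 (0.44 log units; beyond the scatter). Compound 4 is estimated at 220 nM, within 90 nM to 550 nM.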

Compound 4, half-maximal inhibitory concentration: 24000 nM
Estimate against measurement, compound 4: 110-fold (2.04 log units) below; measured number outside the range, above it.
By their numbers in this assay, from the lowest: compounds 3 and 2 (each within the scatter of the next); then compound 1; then compound 4.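

In this assay, chloro on this aromatic carbon gives a far larger change than any exchange among the earlier groups: a 300-fold higher number from compound 3 to compound 4 (2.48 log units; beyond the scatter) for the pentylamino comparison, a 180-fold higher number from compound 2 to compound 4 (2.27 log units; beyond the scatter) for the methylamino comparison and an 89-fold higher number from compound 1 to compound 4 (1.95 log units; beyond the scatter) for the 2-oxopiperidin-1-yl comparison. The earlier steps shown here were modest at most, so they did not show how sensitive this position can be. Nothing at hand accounts for the size of these steps. From the compounds shown here alone, whether a primary amine, a hydroxyl or a methoxy on this carbon would fall near compound 3 or near compound 4 remains open.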